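A few compounds are considered here, and "the series" means these few. Any claim that something is new, unique, unknown or untested is made for them only; others in the source may bear on it.

Compound 1 `O=C(CI)NCCCCC(=O)NCCCCCCNc1ncnc2c1ncn2[C@@H]1O[C@H](COP(=O)(O)OP(=O)(O)OP(=O)(O)O)[C@@H](O)[C@H]1O` gives 0% in an assay on isolated protein for inhibition of hexokinase-3 (Rattus norvegicus), with a stated time of 6 h, tested at 10 mM; a higher number here means more inhibition at the concentration tested (going by the name of the read-out), a lower number less inhibition. Compound 2 `O=C(CI)NCCCC(=O)NCCCCCCNc1ncnc2c1ncn2[C@@H]1O[C@H](COP(=O)(O)OP(=O)(O)OP(=O)(O)O)[C@@H](O)[C@H]1O` gives 0%, so compound 2 stands level with compound 1 at the digits shown, and the single recorded step no change at the digits printed from compound 1 to compound 2 (within the scatter) lies within the scatter. Compound 3 `CC(=O)NCCCCCCCCNc1ncnc2c1ncn2[C@@H]1O[C@H](COP(=O)(O)OP(=O)(O)OP(=O)(O)O)[C@@H](O)[C@H]1O` differs from compound 2 by a group of 6 heavy atoms (4 carbon, 1 nitrogen, 1 oxygen; no ring) in place of a group of 11 heavy atoms (6 carbon, 2 nitrogen, 2 oxygen, 1 iodine; no ring), on a saturated chain carbon, six bonds along the chain from a nitrogen on an aromatic ring. For the measured compounds named here, only that one step bears on this change, and it showed nothing beyond the scatter, so no step beyond the scatter is expected from compound 2 to compound 3 either: the expected step is no change at the digits printed from compound 2 to compound 3 (within the scatter). For compound 3 the expected value is 0%, within 0% to 10%.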

Compound 3, a percentage reported as inhibition, at one concentration (the size of the read-out at that concentration, not a potency): 0%
Beside the measured number, compound 3's estimate shows no gap at the digits printed; the measured number falls inside the stated range.
By their numbers in this assay, from the lowest: compounds 1, 2 and 3 (each within the scatter of the next).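

Exchanging the iodine-bearing group for 2-acetamidoethyl, on a saturated chain carbon, six bonds along the chain from a nitrogen on an aromatic ring, gives no change at the digits printed from compound 2 to compound 3 (within the scatter) in this assay, and likewise no change at the digits printed from compound 1 to compound 3 (within the scatter). Dropping the iodine and the inner amide therefore leaves the reading where it was, so this position now shows a flat result for a larger structural change than the earlier chain shortening. No measurement here accounts for the flat reading. As far as these compounds go, whether a terminal amine, a carboxylic acid or a longer chain at this position would give any inhibition in this assay stays open.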